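Fluorophenyl Isomers and Cytotoxicity on a Shared Core

This account rests on a few compounds, and the source may have more. Where it says the series, first, only, none or still open, it means among the compounds named here.

Measured compounds:
compound 1 `Cc1ccncc1-c1ccc2[nH]c(=O)nc(-c3ccccc3)c2c1`: > 50000 nM
compound 2 `Cc1cncc(-c2ccc3[nH]c(=O)nc(-c4ccccc4)c3c2)c1`: > 50000 nM
compound 3 `O=c1nc(-c2ccccc2)c2cc(-c3ccccc3F)ccc2[nH]1`: 50000 nM

Among the measured compounds shown here, in an ADME assay on THP-1 cells (Homo sapiens) for cytotoxicity, read by MTT assay, with a stated time of 72 h (on this read-out higher numbers stand for an effect only at larger amounts of compound and lower numbers for an effect already at smaller amounts), compound 3 gives 50000 nM, the only actual number among the three compounds. Compound 1 is reported in this assay only as a limit, > 50000 nM. Compound 2 likewise stands only at a limit, > 50000 nM. The step of a number no higher from compound 1 to compound 3 (the limit leaves the size open) and the step of a number no higher from compound 2 to compound 3 (the limit leaves the size open) therefore leave their sizes open, and the step that the two limits leave unreadable from compound 1 to compound 2 cannot be read at all because of the limit of > 50000 nM in this assay, at which 2 of the 3 values shown sit.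

Compound 4 `O=c1nc(-c2ccccc2)c2cc(-c3cccc(F)c3)ccc2[nH]1` differs from compound 3 in one place: 3-fluorophenyl in place of 2-fluorophenyl on an aromatic carbon. For the measured compounds named here, none of the measured steps exchanges one fluorophenyl for another, and none of them yields a readable size, so there is no step that bears directly on this change. Compound 4 is therefore expected to show a step of no change at the digits printed from compound 3 to compound 4 (within the scatter) that stays within the scatter. Compound 4 is estimated at 50000 nM in this assay, between 25000 nM and 100000 nM, with a real chance that only a limit is reported.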

Compound 4, half-maximal effective concentration: > 50000 nM
Compound 4: a limit, no number; the forecaster's own chance of this, stated with the estimate: 60%; the middle value sits exactly at the limit.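

In this assay, among the compounds shown here, the first exchange of one fluorophenyl for another, 3-fluorophenyl in place of 2-fluorophenyl on an aromatic carbon, gives a number no lower from compound 3 to compound 4 (the limit leaves the size open). This shows that the two isomers need not read alike at this position, though only the direction is fixed, and compound 4 carries a limit rather than a number. From the compounds shown here alone, the size of this step stays open, and the steps to compound 4 from compound 1 and from compound 2 cannot be read at all, because most of the series sits at one value: the limit of > 50000 nM in this assay, at which 3 of the 4 values shown sit.

The compounds shown leave open how far compound 4 lies past that limit. They also leave open whether 4-fluorophenyl, or a phenyl group carrying an amine or a carboxylic acid, would give an effect at smaller amounts at this position.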